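A few compounds are considered here, and "the series" means these few. Any claim that something is new, unique, unknown or untested is made for them only; others in the source may bear on it.

Of the compounds shown here, two have been measured in a functional assay for antagonist activity at Neuropeptide Y receptor type 2 (Homo sapiens); on this read-out higher numbers stand for weaker inhibition and lower numbers for stronger inhibition. Compound 1, `CCOC(=O)c1ccc(NC(=S)N2CCC(C(c3ccccc3)c3ccccc3)CC2)cc1`, carries a thiourea linker and an ester on its outer ring; in this assay compound 1 gives 6760 nM. Compound 2, `CCOc1ccc(OC(=O)N2CCC(C(O)(c3ccccc3)c3ccccc3)CC2)cc1`, has a carbamate linker, a hydroxyl on the central carbon and an ethoxy group on its outer ring; in this assay compound 2 gives 1580 nM. Compound 2 thus stands at the lower, that is stronger, end of the two numbers, and its gap to compound 1 lies beyond the scatter. These two compounds differ in several places at once. Going by the values given here, no single structural step between them can be read off.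

Among the compounds with values here, compound 3, `CS(=O)(=O)Nc1ccc(OC(=O)N2CCC(C(O)(c3ccccc3)c3ccccc3)CC2)cc1`, keeps the whole frame of compound 2 and changes only one group: methanesulfonamido in place of ethoxy on an aromatic carbon. Within the data shown here, no measured pair shows what such a change does here, so the expectation rests on compound 2 alone. The step from compound 2 to compound 3 is expected to be small, a 1.0-fold higher number from compound 2 to compound 3 (0.01 log units; within the scatter), without a clear direction beyond the scatter. Compound 3 is therefore estimated at 1600 nM, with a range from 500 nM to 5000 nM.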

Compound 3, half-maximal inhibitory concentration: 394 nM
Compound 3: the middle estimate sits 4.1-fold (0.61 log units) above what was measured, and the stated range ends above it.
By their numbers in this assay, from the lowest: compound 3; then compound 2; then compound 1.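

In this assay, methanesulfonamido in place of ethoxy on an aromatic carbon, para to a large group, gives a 4.0-fold lower number from compound 2 to compound 3 (0.60 log units; beyond the scatter). Going by these compounds alone, this is the first change here that can be read on its own, and it shows that the number responds to what sits at this position while the rest of the frame stays fixed. The entering group has 5 heavy atoms against 3 and brings 1 hydrogen-bond donor and 2 acceptors where ethoxy has 0 donors and 1 acceptor, but a single pair cannot tell which of these differences goes with the lower number, and nothing measured here bears on why it fell.

The compounds shown leave open what other groups at this position would do, for example an amine, an acetamido group or a longer chain such as butoxy, any of which would help to show which part of methanesulfonamido goes with the change. They also leave open whether the same swap would give a similar step on a frame with a thiourea linker, as in compound 1, instead of the carbamate linker and hydroxyl shared by compound 2 and compound 3.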